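Dichlorophenyl Swap Tested Against Cytotoxicity Limits

The compounds below may be only part of what the source reports. "The series", "measured", "known", "first", "only" and "open" are said of these compounds alone.

Compound 1 `CCOC(=O)CCCCCOc1cccc(CN(C(=O)c2ccc(-c3cccc(OC(C)C)c3)cc2)C(C)C)c1` was examined in an ADME assay on BJ cells (Homo sapiens) for cytotoxicity, read by CellTiter-Glo and resazurin assay, with a stated time of 72 h (on this read-out higher numbers stand for an effect only at larger amounts of compound and lower numbers for an effect already at smaller amounts), where compound 1 gives > 26000 nM, which is a limit of the assay rather than a number. Compound 2 `CCOC(=O)CCCCCOc1cccc(CN(C(=O)c2ccc(-c3cccc(Oc4ccccc4)c3)cc2)C(C)C)c1` returns > 19600 nM, also a limit. Compound 3 `CCOC(=O)CCCCCOc1cccc(CN(C(=O)c2ccc(-c3cccc(OCc4ccccc4)c3)cc2)C(C)C)c1` returns > 26000 nM, again a limit. Two of the three values shown sit at the limit of > 26000 nM in this assay, at which 2 of the 3 values shown sit, and one at the limit of > 19600 nM in this assay, at which 1 of the 3 values shown sits, so the steps a step that the two limits leave unreadable from compound 1 to compound 2, a step that the two limits leave unreadable from compound 1 to compound 3 and a step that the two limits leave unreadable from compound 2 to compound 3 have no readable size. Compound 4 `CCOC(=O)CCCCCOc1cccc(CN(C(=O)c2ccc(-c3ccc(Cl)c(Cl)c3)cc2)C(C)C)c1` has not yet been measured; it differs from compound 1 by 3,4-dichlorophenyl in place of 3-isopropoxyphenyl on an aromatic carbon. For the measured compounds named here, no measured step reads a change at the group on the oxygen on the aromatic ring, and all three measured compounds rest at a limit. Compound 4 is therefore expected to give 26000 nM (range 10000 nM to 60000 nM) in this assay. The step of a number no higher from compound 1 to compound 4 (the limit leaves the size open) that this estimate implies is expected to stay within the scatter.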

Compound 4, half-maximal effective concentration: > 26000 nM
Compound 4 gave a limit, no number; the forecaster's own chance of this, stated with the estimate: 80%; the middle value lies on the limit itself.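

Compound 1 and compound 4 both rest at a limit in this assay, and the step between them cannot be read. The compounds shown leave open whether 3,4-dichlorophenyl and 3-isopropoxyphenyl differ at all on this read-out.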